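A few compounds are considered here, and "the series" means these few. Any claim that something is new, unique, unknown or untested is made for them only; others in the source may bear on it.

Working notes on the series. Within the data shown here, compound 1 `O=C1O[C@H]([C@@H](O)Cn2cc(-c3cccc(O)c3)nn2)C(OCc2ccccc2)=C1OCc1ccccc1` is the only member with a number in hand: in a functional assay on HepG2 cells (Homo sapiens) for antiproliferative activity, read by MTT assay, with a stated time of 72 h (a lower number here means a stronger inhibitor, a higher number a weaker inhibitor), compound 1 gives 62700 nM. Compound 2 `CC(C)(C)OC(=O)N1CCN(C(=S)SCc2cn(C[C@H](O)[C@H]3OC(=O)C(OCc4ccccc4)=C3OCc3ccccc3)nn2)CC1` reaches only a limit of the assay, > 100000 nM, and that is the one limit here, (the limit of > 100000 nM in this assay, at which 1 of the 2 values shown sits). Compound 3 `O=C1O[C@H]([C@@H](O)Cn2cc(CNS(=O)(=O)c3ccc(F)cc3)nn2)C(OCc2ccccc2)=C1OCc1ccccc1` differs from compound 1 by (((4-fluorophenyl)sulfonyl)amino)methyl in place of 3-hydroxyphenyl on an aromatic carbon. Among the measured compounds shown here, no step between measured compounds is available, so the effect of this change has no measured anchor; the expected step of a 1.1-fold higher number from compound 1 to compound 3 (0.05 log units; within the scatter) is small, in no clear direction, and not beyond the scatter. Compound 3 is therefore estimated at 70000 nM in this assay, in the range 25000 nM to 200000 nM, with a real chance that only a limit is reported.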

Compound 3, half-maximal inhibitory concentration: 18300 nM
Estimate against measurement, compound 3: 3.8-fold (0.58 log units) above; the whole stated range lies above it.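

In this assay, this aromatic carbon of the five-membered aromatic ring with 3 nitrogen proves responsive to the group it carries: (((4-fluorophenyl)sulfonyl)amino)methyl in place of 3-hydroxyphenyl gives a 3.4-fold lower number from compound 1 to compound 3 (0.53 log units; beyond the scatter) and thus a modest change beyond the scatter. No measured property among the data shown bears on this step, so it remains without a stated cause. The compounds shown leave open which part of the entering group carries the step, and whether an amine, a carboxylic acid or a longer chain on this carbon would shift the number further.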